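The source may hold more compounds than are shown below. What is called first, only, known or untested is meant among the compounds shown, and "the series" means these compounds.

Compound 1 `CCNCc1cc(-c2c(C(=O)NCC)noc2-c2cc(C(C)C)c(O)cc2O)on1` is the reference point of this set. In a functional assay on HCT-116 cells (Homo sapiens) for inhibition (a lower number here means a stronger inhibitor, a higher number a weaker inhibitor), compound 1 gives 45 nM. Compound 2 `CCNC(=O)c1noc(-c2cc(C(C)C)c(O)cc2O)c1-c1cc(CNC(C)C)no1` carries methyl in place of hydrogen on a saturated chain carbon bound to an amine nitrogen and a saturated chain carbon; in this assay compound 2 gives 109 nM, and the step is a 2.4-fold higher number from compound 1 to compound 2 (0.38 log units; beyond the scatter). Compound 3 `CCNC(=O)c1noc(-c2cc(C(C)C)c(O)cc2O)c1-c1cc(C(=O)NC)no1` has a different core, which is separated from that of compound 1 by methylcarbamoyl in place of (ethylamino)methyl on an aromatic carbon; in this assay compound 3 gives 124 nM, with a step of a 2.8-fold higher number from compound 1 to compound 3 (0.44 log units; beyond the scatter). Compound 2 and compound 3 lie close to each other, as a 1.1-fold higher number from compound 2 to compound 3 (0.06 log units; within the scatter) shows.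

Compound 4 `CCNC(=O)c1cc(-c2c(C(=O)NCC)noc2-c2cc(C(C)C)c(O)cc2O)on1` is not yet measured. It differs from compound 3 by methyl in place of hydrogen on a saturated chain carbon bound to an amide-type nitrogen. This is the same kind of change as that from compound 1 to compound 2, but the place is not the same: there the carbon was bound to an amine nitrogen and a saturated chain carbon, here it is bound to an amide-type nitrogen. Among the compounds with values here, the single earlier example, a 2.4-fold higher number from compound 1 to compound 2 (0.38 log units; beyond the scatter), was a modest loss. Compound 4 is therefore expected to sit near compound 3 or slightly above it, a step estimated at a 1.3-fold higher number from compound 3 to compound 4 (0.11 log units; within the scatter). The estimate for compound 4 in this assay is 160 nM, between 60 nM and 420 nM.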

Compound 4, half-maximal inhibitory concentration: 14 nM
For compound 4 the middle estimate is 11-fold (1.06 log units) above the measured one; measured number below the stated range.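

In this assay, going from methylcarbamoyl to ethylcarbamoyl gives an 8.9-fold lower number from compound 3 to compound 4 (0.95 log units; beyond the scatter), and the ethylcarbamoyl group of compound 4 also compares well with the two amine side chains, with a 7.8-fold lower number from compound 2 to compound 4 (0.89 log units; beyond the scatter) and a 3.2-fold lower number from compound 1 to compound 4 (0.51 log units; beyond the scatter). The change of methyl in place of hydrogen therefore does not carry over from one core to the other, not even in direction: the same change on two cores in this assay, a 2.4-fold higher number (0.38 log units; beyond the scatter) from compound 1 to compound 2 and an 8.9-fold lower number (0.95 log units; beyond the scatter) from compound 3 to compound 4, 21-fold (1.33 log units) apart, beyond the scatter of two such steps This rests on a single pair for each core, so it shows that the step depends on where the change is made in these compounds, but it does not show why, and it gives no rule for any further core.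

The compounds shown leave open whether the gain from methylcarbamoyl to ethylcarbamoyl continues with a longer chain on the amide nitrogen, such as propylcarbamoyl, or with a branched one, such as isopropylcarbamoyl. They also leave open how a plain carbamoyl or a carboxylic acid on the same aromatic carbon would compare.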